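Swapping the Alkene Aryl Group in Two Inactive Cyanoacrylamides

The source may hold more compounds than are shown below. What is called first, only, known or untested is meant among the compounds shown, and "the series" means these compounds.

Measured so far:
compound 1, `COc1ccc(CNC(=O)/C(C#N)=C/c2ccc[nH]2)cc1` — > 50000 nM
compound 2, `N#C/C(=C\c1ccc[nH]1)C(=O)NCc1ccc(Cl)c(Cl)c1` — > 50000 nM

In a functional assay on DU-145 cells (Homo sapiens) for inhibition, read by MTT assay, with a stated time of 72 h (on this read-out lower numbers stand for stronger inhibition of growth and higher numbers for weaker inhibition of growth), compound 1 reaches only the limit of the assay, giving > 50000 nM. In this assay compound 2 likewise reaches only the limit, giving > 50000 nM. Compound 2 therefore stands at the top of the numbers shown, and both values sit at the same boundary (the limit of > 50000 nM in this assay, at which 2 of the 2 values shown sit); no real difference between the two can be read.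

Compound 3, `COc1ccc(/C=C(\C#N)C(=O)NCc2ccc(Cl)c(Cl)c2)cc1`, differs from compound 2 by 4-methoxyphenyl in place of 1H-pyrrol-2-yl on a double-bonded chain carbon bound to a double-bonded chain carbon. Within the data shown here, no measured pair shows the effect of such a change, so the size of the step rests on the two limits alone. A step from compound 2 to compound 3 in this assay is expected to stay within the scatter, perhaps modestly downward, and is given as an at least 1.2-fold lower number from compound 2 to compound 3 (0.09 log units; that floor lies within the scatter). Compound 3 is therefore estimated at 40000 nM in this assay, with a range from 15000 nM to 100000 nM.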

Compound 3, concentration for 50% growth inhibition: 70000 nM
Estimate against measurement, compound 3: 1.8-fold (0.24 log units) below; the measured number falls inside the stated range.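

No step from compound 2 to compound 3 can be read in this assay, because the value of compound 2 is a limit and not a number: the limit of > 50000 nM in this assay, at which 2 of the 3 values shown sit.

The compounds shown leave open whether 4-methoxyphenyl in place of 1H-pyrrol-2-yl changes growth inhibition at all.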